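Where Compound 3 Stands and What Compound 4 May Bring

The source may report more compounds than this note shows. Statements on the series, on what has been measured and on what is new or still open speak of the compounds shown alone.

Compound 3 `Cc1ccc(C(=O)OC(CCN(C)C)c2ccc(Cl)cc2)cc1` gives 56% in an assay on NIH3T3 cells with Urotensin-2 receptor (Homo sapiens) as the target (a higher number here means a larger maximal response, a lower number a smaller maximal response), the lowest of the three numbers. Compound 1 `COc1ccc(C(=O)OC(CCN(C)C)c2ccc(Cl)cc2)cc1` gives 84%, and compound 2 `CCc1ccccc1C(=O)OC(CCN(C)C)c1ccc(Cl)cc1` gives 128%; the steps of a number 28 percentage points lower from compound 1 to compound 3 (beyond the scatter) and a number 72 percentage points lower from compound 2 to compound 3 (beyond the scatter) both lie beyond the scatter. Compound 4 `Cc1ccccc1NC(=O)OC(CCN(C)C)c1ccc(Cl)cc1` differs from compound 3 by (2-methylphenyl)amino in place of 4-methylphenyl on a carbonyl carbon. The measured steps that bear on this change are a number 44 percentage points higher from compound 1 to compound 2 (beyond the scatter) and a number 72 percentage points lower from compound 2 to compound 3 (beyond the scatter), both large, and in both compound 2 with its 2-ethylphenyl group stands highest. For the measured compounds named here, the (2-methylphenyl)amino group has no measured counterpart, so the step expected here, a number 34 percentage points higher from compound 3 to compound 4 (beyond the scatter), points upward but with wide uncertainty. Compound 4 is therefore expected to give 90% in this assay, with a range from 50% to 135%.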

Compound 4, largest response reached (reported as efficacy), in percent of the reference or control that the assay uses: 176%
For compound 4 the middle estimate is 86 percentage points below the measured one; measured number outside the range, above it.
By their numbers in this assay, from the lowest: compound 3; then compound 1; then compound 2; then compound 4.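

Putting (2-methylphenyl)amino on the carbonyl carbon, a group with a hydrogen-bond donor, gives a number 120 percentage points higher from compound 3 to compound 4 (beyond the scatter) in this assay, and the same change gives a number 48 percentage points higher from compound 2 to compound 4 (beyond the scatter) and a number 92 percentage points higher from compound 1 to compound 4 (beyond the scatter). The 2-ethylphenyl group is thus not the upper limit at this position, and a group joined through nitrogen exceeds all three groups joined through a ring carbon. Nothing available here explains this rise. Going by these compounds, whether it belongs to the nitrogen link or to the ring's methyl stays open, as does what a phenylamino or cyclohexylamino group would give on this carbon.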